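Working notes: from compound 2 to compound 4

This account rests on a few compounds, and the source may have more. Where it says the series, first, only, none or still open, it means among the compounds named here.

In a functional assay on DU-145 cells (Homo sapiens) for inhibition, read by trypan blue exclusion, with a stated time of 96 h (on this read-out higher numbers stand for weaker inhibition of growth and lower numbers for stronger inhibition of growth), compound 1 (`O=C(/C(=C\c1ccc(Br)cc1)SCc1ccc(Cl)cc1)c1ccc(Br)cc1`) gives 1000 nM as its reading, and compound 2 (`O=C(/C(=C\c1cc(I)c(O)c(I)c1)SCc1ccc(Br)cc1)c1ccc(Br)cc1`) gives 1000 nM as its reading. The two stand level and together hold the lowest number of the three measured. Compound 3 (`CCOc1cc(/C=C(\Cc2ccc(Cl)cc2Cl)C(=O)c2ccc(Cl)cc2)ccc1O`) reads 10000 nM and its gap to compound 2 lies beyond the scatter.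

Compound 4 (`O=C(/C(=C\c1ccc(O)c(C(=O)O)c1)SCc1ccc(Br)cc1)c1ccc(Br)cc1`) is not yet measured. It differs from compound 2 in one place, on a double-bonded chain carbon bound to a double-bonded chain carbon, where 3-carboxy-4-hydroxyphenyl stands in place of 4-hydroxy-3,5-diiodophenyl: 3-carboxy-4-hydroxyphenyl in place of 4-hydroxy-3,5-diiodophenyl on a double-bonded chain carbon bound to a double-bonded chain carbon is the whole change.

Among the compounds with values here, no measured pair isolates this change, so the step in this assay can only be estimated. A moderate step to a higher number is expected, with no step beyond the scatter still possible. The measured span, from compound 2 at 1000 nM to compound 3 at 10000 nM as its top, frames this expectation. The estimated move is a 2.5-fold higher number from compound 2 to compound 4 (0.40 log units; beyond the scatter) in the number read. Compound 4 is expected at 2500 nM with an estimated range of 700 nM to 10000 nM in this series.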

Compound 4, concentration for 50% growth inhibition: 10000 nM
For compound 4 the middle estimate is 4.0-fold (0.60 log units) below the measured one; low and high end bracket the measured number.
By their numbers in this assay, from the lowest: compounds 1 and 2 (each within the scatter of the next); then compounds 3 and 4 (each within the scatter of the next).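

In this assay, within the data shown here, the first readable step at this position is a 10-fold higher number from compound 2 to compound 4 (1.00 log units; beyond the scatter), with the rest of the molecule unchanged. The group on a double-bonded chain carbon bound to a double-bonded chain carbon therefore matters to the reading, and 3-carboxy-4-hydroxyphenyl does not stand in for 4-hydroxy-3,5-diiodophenyl here, although both groups hold a hydroxy on one six-membered aromatic ring of carbon only. The change removes two iodine atoms and adds a carboxy group in a single step, and nothing available explains the loss.

As far as these compounds go, it remains open whether losing the iodine atoms or gaining the carboxy group accounts for the step. A methyl ester in place of the carboxy group, or a monoiodo phenyl with the hydroxy retained, would separate the two.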